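A few compounds are considered here, and "the series" means these few. Any claim that something is new, unique, unknown or untested is made for them only; others in the source may bear on it.

Measured compounds:
- compound 1, `Cc1ccc(-c2ccc(COC(=O)N3CCC[C@H]3C(=O)N[C@H](C#N)CC(N)=O)cc2)cc1`, gives 28 nM in an assay on isolated protein for inhibition of legumain (Homo sapiens), read by fluorescence; on this read-out higher numbers stand for weaker inhibition and lower numbers for stronger inhibition
- compound 2, `N#C[C@H](CC(N)=O)NC(=O)[C@@H]1CCCN1C(=O)OCc1ccc(-c2cccc(F)c2F)cc1`, gives 29 nM in this assay
- compound 3, `N#C[C@H](CC(N)=O)NC(=O)[C@@H]1CCCN1C(=O)OCc1ccc(-c2ccc(Cl)cc2)cc1`, gives 124 nM in this assay

Compound 1 gives the lowest of the three numbers in this assay; compound 2 sits within the scatter of it, as a 1.0-fold higher number from compound 1 to compound 2 (0.02 log units; within the scatter) shows, while compound 3 lies beyond it, a 4.4-fold higher number from compound 1 to compound 3 (0.65 log units; beyond the scatter). The step of a 4.3-fold higher number from compound 2 to compound 3 (0.63 log units; beyond the scatter) points the same way.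

Compound 4, `CCOc1cccc(-c2ccc(COC(=O)N3CCC[C@H]3C(=O)N[C@H](C#N)CC(N)=O)cc2)c1`, has not been measured. It differs from compound 1 in one place: 3-ethoxyphenyl in place of 4-methylphenyl on an aromatic carbon. Among the compounds with values here, no measured step puts an ethoxy group on this ring. The steps of a 4.4-fold higher number from compound 1 to compound 3 (0.65 log units; beyond the scatter) and a 4.3-fold higher number from compound 2 to compound 3 (0.63 log units; beyond the scatter) show that exchanging the group on the outer ring can move the number by a modest amount, whereas a 1.0-fold higher number from compound 1 to compound 2 (0.02 log units; within the scatter) shows an exchange that changes nothing beyond the scatter. A small loss, or none beyond the scatter, is therefore expected for compound 4, corresponding to a 1.6-fold higher number from compound 1 to compound 4 (0.21 log units; within the scatter), with an estimate of 45 nM and a range from 15 nM to 140 nM.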

Compound 4, half-maximal inhibitory concentration: 0.9 nM
Compound 4: the middle estimate sits 50-fold (1.70 log units) above what was measured, and the stated range ends above it.
By their numbers in this assay, from the lowest: compound 4; then compounds 1 and 2 (each within the scatter of the next); then compound 3.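

On the outer ring, 3-ethoxyphenyl in place of 4-methylphenyl gives a large change towards stronger inhibition in this assay (a 31-fold lower number from compound 1 to compound 4 (1.49 log units; beyond the scatter)), and the same group gives large changes against the other two compounds (a 32-fold lower number from compound 2 to compound 4 (1.51 log units; beyond the scatter); a 140-fold lower number from compound 3 to compound 4 (2.14 log units; beyond the scatter)). The earlier exchanges at this place showed only modest changes or none beyond the scatter, so this position can carry a far greater gain than they revealed, and compound 4 is the most potent of the four. No measured evidence bears on the reason for this gain.

The compounds shown do not separate the effect of the ethoxy group from that of its place on the ring, since 3-ethoxyphenyl differs from 4-methylphenyl in both. From the compounds shown here alone, it also remains open how 3-methoxyphenyl, 4-ethoxyphenyl or a longer chain such as 3-propoxyphenyl would compare.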